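A few compounds are considered here, and "the series" means these few. Any claim that something is new, unique, unknown or untested is made for them only; others in the source may bear on it.

Measured in a physicochemical assay for lipophilicity, at pH 7.4; on this read-out lower numbers stand for lower lipophilicity and higher numbers for higher lipophilicity:
- compound 1 `Cc1[nH]c2ccccc2c(=O)c1Cc1ccccc1`: 1.93
- compound 2 `COc1ccc2[nH]c(C)c(Cc3ccccc3)c(=O)c2c1`: 2.53

Of these two compounds, compound 2 holds the higher number, 2.53. Compound 3 `Cc1[nH]c2ccc(Cl)cc2c(=O)c1Cc1ccccc1` has not yet been measured in this assay. It differs from compound 2 in one place: chloro in place of methoxy on an aromatic carbon. In plain terms, this puts chloro in place of methoxy on an aromatic carbon.

Going by the values given here, only one measured step bears on this change: a number 0.60 log units higher from compound 1 to compound 2 (beyond the scatter). That modest step came with methoxy in place of hydrogen, so it involves the group that now leaves. Among the compounds with values here, no measured compound carries chloro, and how chloro compares with methoxy remains open. A small rise is therefore expected, possibly no larger than the scatter, and the estimated change is a number 0.12 log units higher from compound 2 to compound 3 (within the scatter). For compound 3 the expected value is 2.65, with an estimated range of 2.25 to 3.05.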

Compound 3, distribution coefficient: 2.79
The estimate for compound 3 lay 0.14 log units below the measured number; measured number inside the range.
By their numbers in this assay, from the lowest: compound 1; then compounds 2 and 3 (each within the scatter of the next).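

At this position on the shared core, chloro in place of methoxy gives a number 0.26 log units higher from compound 2 to compound 3 (within the scatter) in this assay, so the two groups cannot be told apart on this read-out, even though methoxy has 2 heavy atoms and a hydrogen-bond acceptor and chloro has 1 heavy atom and no such acceptor. Chloro in place of hydrogen gives a number 0.86 log units higher from compound 1 to compound 3 (beyond the scatter), so with a number 0.60 log units higher from compound 1 to compound 2 (beyond the scatter) as well, both substituents now stand clear of the scatter relative to hydrogen at this position. Nothing measured here offers a reason for this likeness between the two groups.

As far as these compounds go, how an amine or a carboxylic acid at this position would read in this assay stays open. Also open, from the compounds shown here alone, is whether chloro or methoxy on another carbon of the core would give steps of similar size.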